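The source may report more compounds than this note shows. Statements on the series, on what has been measured and on what is new or still open speak of the compounds shown alone.

In an assay on VSM-A10 cells for antagonist activity at Endothelin-1 receptor (Rattus norvegicus) (on this read-out higher numbers stand for weaker inhibition and lower numbers for stronger inhibition), compound 2, the compound `Cc1noc(NS(=O)(=O)c2cccc3c(N4CCCCC4=O)cccc23)c1C`, gives 270 nM, the lowest of the three numbers recorded so far. Going by the values given here, compound 1, the compound `Cc1noc(NS(=O)(=O)c2ccc(NC(=O)CN)cc2)c1C`, gives 6500 nM in this assay, and compound 3, the compound `Cc1noc(NS(=O)(=O)c2cccc([N+](=O)[O-])c2)c1C`, gives 7800 nM in this assay; both of these stand beyond the scatter above compound 2, and nothing more can be read from those pairs, since no single-point step links them.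

Compound 4, the compound `CCCCCNc1cccc2c(S(=O)(=O)Nc3onc(C)c3C)cccc12`, has not yet been measured in this assay. It differs from compound 2 in one place: pentylamino in place of 2-oxopiperidin-1-yl on an aromatic carbon. Among the compounds with values here, no measured pair in this set shows what such an exchange does, so the expectation rests only on compound 2 and its value 270 nM.

Compound 4 is therefore estimated to stay close to compound 2 in this assay, with a step of a 1.3-fold higher number from compound 2 to compound 4 (0.11 log units; within the scatter) that is expected to fall within or only just beyond the scatter. Compound 4 is expected to give about 350 nM in this assay, with a range from 100 nM to 1200 nM.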

Compound 4, half-maximal inhibitory concentration: 80 nM
Beside the measured number, compound 4's estimate is 4.4-fold (0.64 log units) above it, outside the stated range (below it).
By their numbers in this assay, from the lowest: compound 4; then compound 2; then compounds 1 and 3 (each within the scatter of the next).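

In this assay, replacing 2-oxopiperidin-1-yl with pentylamino on this aromatic carbon gives a 3.4-fold lower number from compound 2 to compound 4 (0.53 log units; beyond the scatter), which shows that this position tolerates an open chain and that neither the six-membered ring nor its carbonyl is needed to reach a lower number. The exchange removes the ring and the carbonyl and adds a hydrogen-bond donor all at once, and this single pair cannot separate these changes. No evidence is available that bears on what lies behind the step.

The compounds shown leave open how the number moves along the chain, from a shorter propylamino to a longer heptylamino. They also leave open whether a piperidin-1-yl ring without the carbonyl, or an N-methyl-N-pentylamino group without the amine hydrogen, would stand nearer compound 2 or compound 4.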